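A few compounds are considered here, and "the series" means these few. Any claim that something is new, unique, unknown or untested is made for them only; others in the source may bear on it.

Measured so far in a functional assay on PC-3 cells (Homo sapiens) for inhibition, read by CellTiter-Glo, with a stated time of 72 h; on this read-out lower numbers stand for higher toxicity in this test and higher numbers for lower toxicity in this test
- compound 1 `CC1=C(C(C)C(=O)N(C)CCN(C)C)c2cc(F)ccc2/C1=C\c1ccc([S+](C)[O-])cc1` gives 44600 nM
- compound 2 `CC1=C(C(C)C(=O)N(CCNC(C)C)C(C)C)c2cc(F)ccc2/C1=C\c1ccc([S+](C)[O-])cc1` gives 15200 nM
- compound 3 `CC1=C(C(C)C(=O)NCCN2CCCC2)c2cc(F)ccc2/C1=C\c1ccc([S+](C)[O-])cc1` gives 32000 nM

Compound 3 stands in the upper part of this narrow spread, level with compound 1 and clear of compound 2. The two steps that place it are a 1.4-fold lower number from compound 1 to compound 3 (0.14 log units; within the scatter) and a 2.1-fold higher number from compound 2 to compound 3 (0.32 log units; beyond the scatter).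

The next compound, compound 4 `CC1=C(C(C)C(=O)N2CCN(CCCN(C)C)CC2)c2cc(F)ccc2/C1=C\c1ccc([S+](C)[O-])cc1`, keeps the shared core and differs only in the group on a carbonyl carbon (4-(3-(dimethylamino)propyl)piperazin-1-yl in place of (2-(pyrrolidin-1-yl)ethyl)amino on a carbonyl carbon). All three measured steps were made at this same place, and the largest of them is a 2.9-fold lower number from compound 1 to compound 2 (0.47 log units; beyond the scatter). For the measured compounds named here, none of the measured compounds carries a piperazine ring, so there is no direct precedent for the new group. Only a small move is therefore expected in this assay, leaning towards a lower number and probably not beyond the scatter. The expected change is a 1.5-fold lower number from compound 3 to compound 4 (0.16 log units; within the scatter). For compound 4 the estimated value is 22000 nM, with an expected range from 9000 nM to 45000 nM.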

Compound 4, half-maximal cytotoxic concentration: > 50000 nM
Compound 4 ended at the assay's limit; the forecaster's own chance of this, stated with the estimate: 8%; at least 2.2-fold (0.35 log units) between middle value and limit.
By their numbers in this assay, from the lowest: compound 2; then compounds 3 and 1 (each within the scatter of the next). At a limit, above all of these: compound 4.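

In this assay compound 4 gives > 50000 nM, which is a limit of the assay and not a number. For the compounds shown here, this is the first group on this carbonyl carbon to reach that limit, so the 4-(3-(dimethylamino)propyl)piperazin-1-yl group does not bring the higher toxicity that the earlier changes at this place might have suggested. Going by these compounds alone, only one comparison is clear, an at least 3.2-fold higher number from compound 2 to compound 4 (0.51 log units; beyond the scatter), while the other two floors, an at least 1.5-fold higher number from compound 3 to compound 4 (0.19 log units; that floor lies within the scatter) and an at least 1.1-fold higher number from compound 1 to compound 4 (0.04 log units; that floor lies within the scatter), lie within the scatter and do not separate compound 4 from compound 3 or compound 1.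

Which part of the new group matters remains open, the piperazine ring or its 3-(dimethylamino)propyl chain. A 4-methylpiperazin-1-yl or a morpholin-4-yl group at this place would help to separate the two.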